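Cytotoxicity on the shared core: neopentyl for 3,4-difluorophenyl

The source may report more compounds than this note shows. Statements on the series, on what has been measured and on what is new or still open speak of the compounds shown alone.

Among the measured compounds shown here, compound 1 `CN(c1ccc2c(c1)S(=O)(=O)C=C(c1c(O)c3cc(F)ccc3n(Cc3ccc(F)cc3)c1=O)N2)S(C)(=O)=O` and compound 2 `CS(=O)(=O)Nc1ccc2c(c1)S(=O)(=O)C=C(c1c(O)c3cc(F)ccc3n(Cc3ccc(F)c(F)c3)c1=O)N2` share one core and differ in more than one place, so no single step connects them. In an ADME assay on 2209-23 cells (Homo sapiens) for cytotoxicity, read by WST assay (on this read-out higher numbers stand for lower toxicity in this test and lower numbers for higher toxicity in this test), compound 1 reaches only the assay limit, > 50000 nM. Compound 2 likewise gives only the limit, > 50000 nM, in this assay. Both values rest at the limit of > 50000 nM in this assay, at which 2 of the 2 values shown sit, so compound 2 stands at the limit with no number to rank it. Compound 3 `CC(C)(C)CCn1c(=O)c(C2=CS(=O)(=O)c3cc(NS(C)(=O)=O)ccc3N2)c(O)c2cc(F)ccc21` differs from compound 2 by neopentyl in place of 3,4-difluorophenyl on a saturated chain carbon bound to an aromatic nitrogen. For the measured compounds named here, with no measured step to draw on, the step of a number no higher from compound 2 to compound 3 (the limit leaves the size open) is expected to be none beyond the scatter. Compound 3 is therefore expected to give 50000 nM in this assay, within 25000 nM to 100000 nM, most likely again as a limit.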

Compound 3, half-maximal cytotoxic concentration: > 50000 nM
Compound 3: only a limit was reported; the forecaster's own chance of this, stated with the estimate: 80%; the middle value lies on the limit itself.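

Compound 2 and compound 3 both rest at the limit in this assay, so no step can be read between them: the limit of > 50000 nM in this assay, at which 3 of the 3 values shown sit.

The compounds shown leave open whether neopentyl in place of 3,4-difluorophenyl shifts this read-out at all.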